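Chloro removal on the terminal phenyl of compound 1

The source may report more compounds than this note shows. Statements on the series, on what has been measured and on what is new or still open speak of the compounds shown alone.

Among the measured compounds shown here, compound 1 `COc1ccccc1N1CCN(CCCCC(=O)NCc2ccccc2-c2ccc(Cl)cc2)CC1` stands at the lowest number of the two measured so far: in an assay on CHO-K1 cells for displacement of a labelled ligand from 5-hydroxytryptamine receptor 7 (Homo sapiens), read by scintillation counting (on this read-out lower numbers stand for stronger inhibition and higher numbers for weaker inhibition), compound 1 gives 25.9 nM, whereas compound 2 `COc1ccccc1N1CCN(CCCC(=O)NCc2ccccc2-c2ccccc2)CC1` gives 64.5 nM, a gap beyond the scatter. Compound 3 `COc1ccccc1N1CCN(CCCCC(=O)NCc2ccccc2-c2ccccc2)CC1` differs from compound 1 by hydrogen in place of chloro on an aromatic carbon. For the measured compounds named here, no measured pair isolates this change, so the expectation rests on compound 1 alone, with compound 2 as a loose outer reference. A modest weakening is expected, of a size near the edge of the scatter. Compound 3 is estimated at 42 nM, with a range from 16 nM to 110 nM. The expected step is a 1.6-fold higher number from compound 1 to compound 3 (0.21 log units; within the scatter).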

Compound 3, inhibition constant: 37.9 nM
The estimate for compound 3 lay 1.1-fold (0.04 log units) above the measured number; low and high end bracket the measured number.
By their numbers in this assay, from the lowest: compounds 1, 3 and 2 (each within the scatter of the next, the first and the last beyond it).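

In this assay, 4-chlorophenyl to phenyl reads as a 1.5-fold higher number from compound 1 to compound 3 (0.17 log units; within the scatter). Among the compounds shown here, this is the first pair to isolate this position, and it shows that chloro on this aromatic carbon is not required for a number in this range, while compound 1 and compound 3 cannot be ranked. Nothing available bears on the reason for this result.

Still open, going by these compounds, is whether methoxy, trifluoromethyl or an amine at this position would move the number beyond the scatter. Also open, on these data alone, is whether chloro elsewhere on this ring would do so.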